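Cyclopentyl in Place of Hydrogen on the Shared Core

The source may hold more compounds than are shown below. What is called first, only, known or untested is meant among the compounds shown, and "the series" means these compounds.

Compound 2 `CCn1c(-c2ccccc2)nc2c(N)ncnc21` has the higher of the two numbers measured in an assay on CHO cells for displacement of a labelled ligand from adenosine receptor A3 (Homo sapiens), read by scintillation counting, with a stated time of 3 h; on this read-out lower numbers stand for stronger inhibition and higher numbers for weaker inhibition: compound 2 gives 5780 nM. Within the data shown here, its only measured neighbour is compound 1 `CCn1c(-c2ccccc2)nc2c(NC3CCCCC3)ncnc21`, which in this assay gives 707 nM; the step of an 8.2-fold higher number from compound 1 to compound 2 (0.91 log units; beyond the scatter) arises from hydrogen in place of cyclohexyl on a nitrogen on an aromatic ring. Compound 3 `CCn1c(-c2ccccc2)nc2c(NC3CCCC3)ncnc21` has not been measured; it differs from compound 2 by cyclopentyl in place of hydrogen on a nitrogen on an aromatic ring. Among the measured compounds shown here, the single measured step that bears on this change is an 8.2-fold higher number from compound 1 to compound 2 (0.91 log units; beyond the scatter), which runs the opposite way to the present change and lies beyond the scatter. Because compound 1 shows an 8.2-fold higher number from compound 1 to compound 2 (0.91 log units; beyond the scatter), the cyclopentyl, one five-membered non-aromatic ring of carbon only, is expected to act much like that cyclohexyl, giving an expected step of a 5.8-fold lower number from compound 2 to compound 3 (0.76 log units; beyond the scatter) toward a lower number. Compound 3 is therefore estimated at 1000 nM, with a range of 400 nM to 3000 nM.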

Compound 3, inhibition constant: 354 nM
For compound 3 the middle estimate is 2.8-fold (0.45 log units) above the measured one; the whole stated range lies above it.
By their numbers in this assay, from the lowest: compounds 3 and 1 (each within the scatter of the next); then compound 2.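

On the nitrogen of the shared core, going from amino to cyclopentylamino gives a 16-fold lower number from compound 2 to compound 3 (1.21 log units; beyond the scatter) in this assay and so shows that the lower number seen with cyclohexyl is not confined to that one ring. Cyclopentyl in place of cyclohexyl gives a 2.0-fold lower number from compound 1 to compound 3 (0.30 log units; within the scatter) and so the two rings cannot be told apart on this read-out. Nothing in the data given explains the difference between either ring and hydrogen.

As far as these compounds go, what a methyl, an open chain such as n-butyl, or a phenyl on that nitrogen would give remains open, so the data cannot say whether a ring is needed at all. Also open, from the compounds shown here alone, is whether cyclopentyl and cyclohexyl would stay this close if the ethyl on the shared core gave way to a propyl.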